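Aminomethoxyphenyl to methylphenyl on the fused core

This account rests on a few compounds, and the source may have more. Where it says the series, first, only, none or still open, it means among the compounds named here.

Compound 1 `COc1ccc(-c2cc3nccc(-c4cc(OC)c(OC)c(OC)c4)n3n2)cc1N` stands lowest of the two numbers recorded so far in a functional assay on B16-F0 cells (Mus musculus) for inhibition, read by CCK-8 assay, with a stated time of 48 h; a higher number here means a weaker inhibitor, a lower number a stronger inhibitor: compound 1 gives 88 nM. Compound 3 `COc1cc(-c2ccnc3cc(-c4cn(C)c5ccccc45)nn23)cc(OC)c1OC` gives 185 nM, a step of a 2.1-fold higher number from compound 1 to compound 3 (0.32 log units; beyond the scatter), with 1-methyl-1H-indol-3-yl in place of 3-amino-4-methoxyphenyl on an aromatic carbon. Compound 2 `COc1cc(-c2cc3nccc(-c4c[nH]c5ccccc45)n3n2)cc(OC)c1OC` is recorded only as a limit, not a number: compound 2 sits at > 10000 nM, which is the limit of > 10000 nM in this assay, at which 1 of the 3 values shown sits.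

Among the compounds with values here, compound 4 `COc1cc(-c2ccnc3cc(-c4cccc(C)c4)nn23)cc(OC)c1OC` is not yet measured. 3-methylphenyl in place of 3-amino-4-methoxyphenyl on an aromatic carbon The only measured step bearing on this change is the one from compound 1 to compound 3, which swapped the same group at the same position and was modest. Compound 4 gives up the hydrogen-bond donor and acceptors counted for the leaving group and brings in none, something that step did not probe. An upward step, somewhat larger than the measured one, is expected from compound 1 to compound 4: a 4.5-fold higher number from compound 1 to compound 4 (0.66 log units; beyond the scatter). Compound 4 is estimated at 400 nM, with an expected range from 120 nM to 1500 nM.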

Compound 4, half-maximal inhibitory concentration: 2220 nM
Beside the measured number, compound 4's estimate is 5.6-fold (0.74 log units) below it; the measured number lies above the stated range.
By their numbers in this assay, from the lowest: compound 1; then compound 3; then compound 4. At a limit, above all of these: compound 2.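

In this assay this aromatic carbon proves more sensitive to its substituent than the earlier step showed: 3-methylphenyl in place of 3-amino-4-methoxyphenyl gives a 25-fold higher number from compound 1 to compound 4 (1.40 log units; beyond the scatter), a large step where 1-methyl-1H-indol-3-yl gave only a modest one. The replacement of 1-methyl-1H-indol-3-yl by 3-methylphenyl is also large, with a 12-fold higher number from compound 3 to compound 4 (1.08 log units; beyond the scatter), so ring count alone does not set the order: among these three, the single-ring groups of compound 1 and compound 4 lie on either side of the fused group of compound 3. Nothing measured here gives a cause for these steps.

Going by these compounds, the change from compound 1 to compound 4 alters the amine, the methoxy and the methyl at once, so the share of each remains open. A 3-aminophenyl, 4-methoxyphenyl or 3-hydroxyphenyl group at this carbon would begin to separate them.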